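Swapping Hydroxy for Amino: Expected Effect on Inhibition

The compounds below may be only part of what the source reports. "The series", "measured", "known", "first", "only" and "open" are said of these compounds alone.

Three compounds have been measured in an assay on isolated protein for inhibition of Apoptosis regulator Bcl-2 (Homo sapiens), read by fluorescence polarization, with a stated time of 60 min; on this read-out lower numbers stand for stronger inhibition and higher numbers for weaker inhibition:

Compound 1 `CCOC(=O)c1nn(-c2ccccc2)c(C)c1-c1ccc(C(=O)NS(=O)(=O)c2ccc3ccccc3c2)cc1C(=O)N1CCc2ccccc2C1` gives 4190 nM
Compound 2 `CCCCc1c(-c2ccc(C(=O)NS(=O)(=O)c3ccc4ccccc4c3)cc2C(=O)N2CCc3ccccc3C2)c(C(=O)O)nn1-c1ccccc1` gives 170 nM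
Compound 3 `CCCCc1c(-c2ccc(C(=O)NS(=O)(=O)c3ccc4ccccc4c3)cc2C(=O)N2Cc3ccccc3C[C@H]2CO)c(CO)nn1-c1ccccc1` gives 11 nM

Compound 3 stands lowest of the three numbers, and both gaps to it lie beyond the scatter: compound 2 is the nearest and compound 1 the furthest. Compound 4 `CCCCc1c(-c2ccc(C(=O)NS(=O)(=O)c3ccc4ccccc4c3)cc2C(=O)N2Cc3ccccc3C[C@H]2CN)c(CO)nn1-c1ccccc1` has not been measured. It differs from compound 3 in one place: amino in place of hydroxy on a saturated chain carbon bound to a saturated ring carbon. Among the measured compounds shown here, no measured pair shows this swap, so its effect is unknown. In this assay a step from compound 3 to compound 4 of a 1.4-fold higher number from compound 3 to compound 4 (0.13 log units; within the scatter) is expected, within the scatter. Compound 4 is estimated at 15 nM, in a range from 4 nM to 60 nM.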

Compound 4, half-maximal inhibitory concentration: 24 nM
Compound 4: the middle estimate sits 1.6-fold (0.20 log units) below what was measured, and the stated range covers the measured number.
By their numbers in this assay, from the lowest: compound 3; then compound 4; then compound 2; then compound 1.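

In this assay, among the compounds shown here, this is the first pair of compounds that differ in one place, and amino in place of hydroxy on a saturated chain carbon bound to a saturated ring carbon gives a 2.2-fold higher number from compound 3 to compound 4 (0.34 log units; beyond the scatter). The step is modest, so the change from hydroxymethyl to aminomethyl costs only a little inhibition at this place. Nothing at hand tells why the step has this size.

Open, on these data alone, is how a dimethylamino group, a methoxy group or a longer chain would read at this same place.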